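Urea aryl swap in a HepG2 cytotoxicity series

The compounds below may be only part of what the source reports. "The series", "measured", "known", "first", "only" and "open" are said of these compounds alone.

Among the measured compounds shown here, compound 1 `CC(NC(=O)/C=C/Oc1ccc(NC(=O)Nc2cc(C(F)(F)F)ccc2Cl)cc1)c1ccccc1` is the only member of the series with a numerical reading in a functional assay on HepG2 cells (Homo sapiens) for inhibition, read by MTT assay, with a stated time of 120 h; on this read-out lower numbers stand for stronger inhibition and higher numbers for weaker inhibition: compound 1 gives 11900 nM. Compound 2 `C/C(=C\C(=O)N1CC(C)OC(C)C1)c1ccc(NC(=O)Nc2ccc(Cl)c(C(F)(F)F)c2)cc1` carries the same urea aryl as the planned compound 3 but a different amide part, and in this assay compound 2 returns only a limit, > 50000 nM, which is the limit of > 50000 nM in this assay, at which 1 of the 2 values shown sits. For the measured compounds named here, compound 2 and compound 1 differ in more than one place, so no single step can be read between them; their two values show only that compound 2 sits at the limit while compound 1 gives a number.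

Compound 3 `CC(NC(=O)/C=C/Oc1ccc(NC(=O)Nc2ccc(Cl)c(C(F)(F)F)c2)cc1)c1ccccc1` is compound 1 with 4-chloro-3-(trifluoromethyl)phenyl in place of 2-chloro-5-(trifluoromethyl)phenyl on an amide-type nitrogen. Going by the values given here, no measured step isolates this change, so the expected step is small in either direction, not clearly beyond the scatter. For compound 3 the estimated value in this assay is 10000 nM, with a range from 3000 nM to 40000 nM. The step expected from compound 1 to compound 3 is a 1.2-fold lower number from compound 1 to compound 3 (0.08 log units; within the scatter).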

Compound 3, half-maximal inhibitory concentration: 14100 nM
The estimate for compound 3 lay 1.4-fold (0.15 log units) below the measured number; the range from low to high includes it.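

In this assay, 4-chloro-3-(trifluoromethyl)phenyl in place of 2-chloro-5-(trifluoromethyl)phenyl on an amide-type nitrogen gives a 1.2-fold higher number from compound 1 to compound 3 (0.07 log units; within the scatter). Among the compounds shown here, this is the first step that can be read, and it shows that this read-out does not tell the two substitution patterns apart: with the same atoms joined differently, the pair stays within the scatter. Compound 2 gives only a limit of the assay, and no step can be read from it to compound 1 or compound 3: the limit of > 50000 nM in this assay, at which 1 of the 3 values shown sits.

Still open, as far as these compounds go, is whether a different group on this amide-type nitrogen, such as an unsubstituted phenyl or a pyridine ring bearing an amine, would give a step beyond the scatter, since the two aryl groups compared here carry the same chlorine and trifluoromethyl substituents. Also open, from the compounds shown here alone, is how the reading responds to a change at the other end of compound 1 and compound 3, for example a carboxylic acid in place of the amide part, with the urea aryl held constant.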